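The source may hold more compounds than are shown below. What is called first, only, known or untested is meant among the compounds shown, and "the series" means these compounds.

Measured compounds in a physicochemical assay for solubility, with a stated time of 18 h, at pH 7.4; a lower number here means a less soluble compound, a higher number a more soluble compound:
compound 1, `COc1cccc(CNCCCNc2ccnc3cc(Oc4ccccc4)ccc23)c1O`: 14500 nM
compound 2, `COc1ccc(F)cc1CNCCCNc1ccnc2cc(Oc3ccccc3)ccc12`: 14500 nM

Compound 1 stands level with compound 2 in this assay, the step of no change at the digits printed from compound 1 to compound 2 (within the scatter) lying within the scatter. That step, 5-fluoro-2-methoxyphenyl in place of 2-hydroxy-3-methoxyphenyl on a saturated chain carbon bound to an amine nitrogen, leaves the other end of the shared core untouched.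

Compound 3, `COc1cccc(CNCCCNc2ccnc3cc(-c4ccc(C(F)(F)F)cc4)ccc23)c1O`, is not yet measured. It differs from compound 1 at that other end: 4-(trifluoromethyl)phenyl in place of phenoxy on an aromatic carbon. Going by the values given here, no measured step touches this aromatic carbon, so the single measured step gives no guide to the size of the change here; it only shows that the series tolerates a swap at the chain end without moving the solubility read-out.

Among the compounds with values here, with no comparable step to lean on, the expectation for compound 3 rests on compound 1 alone and is held loose. Compound 3 is expected to come out lower than compound 1, the estimated step being a 3.6-fold lower number from compound 1 to compound 3 (0.56 log units; beyond the scatter). The estimated solubility of compound 3 is 4000 nM, with a range from 800 nM to 15000 nM.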

Compound 3, solubility: 32000 nM
For compound 3 the middle estimate is 8.0-fold (0.90 log units) below the measured one; the measured number lies above the stated range.
By their numbers in this assay, from the lowest: compounds 1 and 2 (each within the scatter of the next); then compound 3.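

In this assay, the aromatic carbon that carries phenoxy in compound 1 tolerates exchange, with 4-(trifluoromethyl)phenyl in its place giving a 2.2-fold higher number from compound 1 to compound 3 (0.34 log units; beyond the scatter). This is the first step shown at this end of the shared core and, unlike the chain-end step, no change at the digits printed from compound 1 to compound 2 (within the scatter), it lies beyond the scatter, though only modestly: a larger group of 10 heavy atoms against 7, with 0 hydrogen-bond acceptors against 1, comes with a higher number rather than a lower one. Nothing measured on these compounds bears on the reason for this step.

Going by these compounds alone, the single step leaves open whether the higher number goes with the loss of the phenoxy oxygen or with the arrival of the trifluoromethyl group, a question that a plain phenyl at this aromatic carbon would separate. Also open, from the compounds shown here alone, are how an amine or a carboxylic acid on the ring at this carbon would read, and whether 4-(trifluoromethyl)phenyl gives a step of like size when paired with the 5-fluoro-2-methoxyphenyl chain end of compound 2.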